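The compounds below may be only part of what the source reports. "The series", "measured", "known", "first", "only" and "open" are said of these compounds alone.

Measured in a functional assay on COR-L23 cells (Homo sapiens) for antiproliferative activity, read by CellTiter-Glo, with a stated time of 72 h; on this read-out lower numbers stand for stronger inhibition and higher numbers for weaker inhibition:
compound 1 `C[C@H](NC(=O)[C@@H]1CCCN1C)c1ccc(NC(=O)N2CC(c3cccnc3)C2)cc1`: 38 nM
compound 2 `C[C@H](NC(=O)c1cccc(F)c1)c1ccc(NC(=O)N2CC(c3ccc(N)nc3)C2)cc1`: 27 nM
compound 3 `C[C@H](NC(=O)C1CCOCC1)c1ccc(NC(=O)N2CC(c3ccc(N)nc3)C2)cc1`: 110 nM

Compound 3 has the highest number of the three, and its gaps to the other two lie beyond the scatter. Compound 4 `C[C@H](NC(=O)[C@@H]1CCCN1C)c1ccc(NC(=O)N2CC(c3ccc(N)nc3)C2)cc1` changes it in one place: 1-methylpyrrolidin-2-yl in place of oxan-4-yl on a carbonyl carbon. In words, 1-methylpyrrolidin-2-yl replaces oxan-4-yl on a carbonyl carbon. Among the measured compounds shown here, one measured step touches this place: a 4.1-fold higher number from compound 2 to compound 3 (0.61 log units; beyond the scatter). It shows that this group can shift the number, but it does not involve the entering group. Compound 1, at 38 nM, carries that group, though its core is not the same. A modest step to a lower number in this assay is therefore expected. The expected change is a 2.4-fold lower number from compound 3 to compound 4 (0.39 log units; beyond the scatter). The estimate for compound 4 is 45 nM, with a range of 15 nM to 130 nM.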

Compound 4, half-maximal inhibitory concentration: 41 nM
Beside the measured number, compound 4's estimate is 1.1-fold (0.04 log units) above it; measured number inside the range.
By their numbers in this assay, from the lowest: compounds 2, 1 and 4 (each within the scatter of the next); then compound 3.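

In this assay, putting 1-methylpyrrolidin-2-yl in place of oxan-4-yl on the carbonyl carbon gives a 2.7-fold lower number from compound 3 to compound 4 (0.43 log units; beyond the scatter), so two non-aromatic rings with the same number of heavy atoms are not interchangeable here. Compound 4 cannot be told apart from the 3-fluorophenyl compound, with a 1.5-fold higher number from compound 2 to compound 4 (0.18 log units; within the scatter), and the amino group on the aromatic carbon also makes no readable difference, with a 1.1-fold higher number from compound 1 to compound 4 (0.03 log units; within the scatter). Nothing available explains the gap between the two rings. The compounds shown leave open how the mirror-image 1-methylpyrrolidin-2-yl group would compare. On these data alone, a carboxylic acid or an open-chain amine at this carbonyl carbon also remains untested among them.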